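Swapping chloro for isopropyl on the shared core

The compounds below may be only part of what the source reports. "The series", "measured", "known", "first", "only" and "open" are said of these compounds alone.

Compound 1 `CCNC(=O)c1ccc(CN(C)C(=O)c2cc(Cl)c(O)cc2O)cc1` gives 21700 nM
Compound 2 `CCNC(=O)c1ccc(CN(C)C(=O)c2cc(C(C)C)c(O)cc2O)cc1` gives 460 nM
Compound 3 `CNC(=O)c1ccc(CN(C)C(=O)c2cc(Cl)c(O)cc2O)cc1` gives 34800 nM

In a functional assay on NCI-H1975 cells (Homo sapiens) for antiproliferative activity, with a stated time of 72 h (on this read-out higher numbers stand for weaker inhibition of growth and lower numbers for stronger inhibition of growth), compound 3 and compound 1 lie within the usual scatter of each other, and both stand far above compound 2. Compound 4 `CNC(=O)c1ccc(CN(C)C(=O)c2cc(C(C)C)c(O)cc2O)cc1` has not yet been measured. It differs from compound 3 at one place, with isopropyl in place of chloro on an aromatic carbon on an aromatic carbon, ortho to a hydroxy group and para to a hydroxy group.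

The same swap has been measured once, and it gave a 47-fold lower number from compound 1 to compound 2 (1.67 log units; beyond the scatter) as a large step. The other measured step, a 1.6-fold higher number from compound 1 to compound 3 (0.21 log units; within the scatter) on the amide chain, stays within the scatter, so that chain difference gives no reason to expect a different outcome here. Among the compounds with values here, with only one example to go on, the same swap should again lower the number strongly. The step expected in this assay is a 47-fold lower number from compound 3 to compound 4 (1.67 log units; beyond the scatter) by this estimate. Compound 4 is expected at 740 nM within an estimated range of 260 nM to 2100 nM for now.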

Compound 4, concentration for 50% growth inhibition: 860 nM
Compound 4: the middle estimate sits 1.2-fold (0.07 log units) below what was measured; the range from low to high includes it.
By their numbers in this assay, from the lowest: compounds 2 and 4 (each within the scatter of the next); then compounds 1 and 3 (each within the scatter of the next).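

In this assay, isopropyl in place of chloro on this aromatic carbon again gives a large step on a second core, a 40-fold lower number from compound 3 to compound 4 (1.61 log units; beyond the scatter), so the gain no longer rests on a single pair: the same change on two cores in this assay, a 47-fold lower number (1.67 log units; beyond the scatter) from compound 1 to compound 2 and a 40-fold lower number (1.61 log units; beyond the scatter) from compound 3 to compound 4, 1.2-fold (0.07 log units) apart, within the scatter of two such steps. Hydrogen in place of methyl on the amide chain stays within the scatter with isopropyl present, a 1.9-fold higher number from compound 2 to compound 4 (0.27 log units; within the scatter), just as it did with chloro: the same change on two cores in this assay, a 1.6-fold higher number (0.21 log units; within the scatter) from compound 1 to compound 3 and a 1.9-fold higher number (0.27 log units; within the scatter) from compound 2 to compound 4, 1.2-fold (0.07 log units) apart, within the scatter of two such steps. Across these four compounds, the group on the aromatic carbon separates the numbers, while this chain difference does not move them beyond the scatter.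

The compounds shown leave open how other groups at this position, such as methyl, tert-butyl or methoxy, would compare, and what it is about isopropyl that lowers the number. They also leave open how an amine or a carboxylic acid on the amide chain would behave.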